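Replacing a Fused Ring with a Methylpiperidine

A few compounds are considered here, and "the series" means these few. Any claim that something is new, unique, unknown or untested is made for them only; others in the source may bear on it.

In a functional assay on HeLa cells (Homo sapiens) for antiproliferative activity, read by CCK-8 assay, with a stated time of 72 h, tested at 2 uM (on this read-out higher numbers stand for a stronger effect at the one concentration tested and lower numbers for a weaker effect), compound 2 `Nc1ccccc1NC(=O)c1ccc(CSC(=S)N2CCCc3ccccc32)cc1` gives 26.1%, the lowest of the two numbers measured; compound 1 `Nc1ccccc1NC(=O)c1ccc(CSC(=S)N2CCc3ccccc32)cc1` gives 38%. Compound 3 `CC1CCCCN1C(=S)SCc1ccc(C(=O)Nc2ccccc2N)cc1` differs from compound 2 by 2-methylpiperidin-1-yl in place of 1,2,3,4-tetrahydroquinolin-1-yl on a thiocarbonyl carbon. Among the measured compounds shown here, the only measured step, a number 11.9 percentage points lower from compound 1 to compound 2 (beyond the scatter), altered a different part of the same group, so it bears only loosely on this change, and no measured step shows what leaving out the six-membered aromatic ring does. The expected step is therefore small, a number 1.1 percentage points lower from compound 2 to compound 3 (within the scatter), with a wide range. Compound 3 is estimated at 25%, between 10% and 45%.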

Compound 3, a percentage reported as inhibition, at one concentration (the size of the read-out at that concentration, not a potency): 45.5%
Beside the measured number, compound 3's estimate is 20.5 percentage points below it; measured number above the stated range.
By their numbers in this assay, from the lowest: compound 2; then compounds 1 and 3 (each within the scatter of the next).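

In this assay, the change to 2-methylpiperidin-1-yl on the thiocarbonyl carbon gives a number 19.4 percentage points higher from compound 2 to compound 3 (beyond the scatter), so the six-membered aromatic ring of the 1,2,3,4-tetrahydroquinolin-1-yl group is not required for the effect at this concentration. Against 2,3-dihydro-1H-indol-1-yl, the same group gives a number 7.5 percentage points higher from compound 1 to compound 3 (within the scatter), so these two groups cannot be told apart here. Nothing available explains why the aromatic ring's absence goes with the higher number.

Going by these compounds, the ring's loss and the methyl group's arrival come together in compound 3, so their separate contributions remain unknown. Plain piperidin-1-yl or morpholin-4-yl at this place would be open questions too.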